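The source may report more compounds than this note shows. Statements on the series, on what has been measured and on what is new or still open speak of the compounds shown alone.

Working notes on the series. For the measured compounds named here, compound 1 `Cc1ccc(Cn2cc(COc3ccc4c(=O)ccoc4c3)nn2)cc1` is the weaker of the two measured compounds in a functional assay on QGY7701 cells (Homo sapiens) for cytotoxicity, read by MTT assay, with a stated time of 48 h; a lower number here means a stronger inhibitor, a higher number a weaker inhibitor: compound 1 gives 68500 nM, the highest number among the two measured, while compound 2 `O=c1ccoc2cc(OCc3cn(Cc4ccc(F)cc4)nn3)ccc12` gives 14400 nM, and the single one-place step a 4.8-fold lower number from compound 1 to compound 2 (0.68 log units; beyond the scatter) is the only measured step available to judge a change at this position. Compound 3 `N#Cc1ccc(Cn2cc(COc3ccc4c(=O)ccoc4c3)nn2)cc1` has not yet been measured. It differs from compound 1 by cyano in place of methyl on an aromatic carbon. Going by the values given here, the only step that bears on this change is the one from compound 1 to compound 2, which replaced the same methyl group with a different substituent and gave a modest improvement. By analogy, a step of similar or somewhat smaller size in the same direction is expected, within the uncertainty of relying on one comparison, as a 2.7-fold lower number from compound 1 to compound 3 (0.44 log units; beyond the scatter). For compound 3 the estimate in this assay is therefore 25000 nM, with a range from 8000 nM to 70000 nM.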

Compound 3, half-maximal inhibitory concentration: > 100000 nM
Compound 3: a limit, no number (the forecaster's own chance of this, stated with the estimate: 5%); middle value at least 4.0-fold (0.60 log units) away from the limit.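

In this assay compound 3 gives a limit and not a number: the limit of > 100000 nM in this assay, at which 1 of the 3 values shown sits.

Putting cyano in place of methyl gives an at least 1.4-fold higher number from compound 1 to compound 3 (0.16 log units; that floor lies within the scatter), so the lower number seen with fluoro does not carry over to cyano at this position. Against fluoro the separation is clearer, with an at least 6.9-fold higher number from compound 2 to compound 3 (0.84 log units; beyond the scatter), which shows that the two replacements of methyl do not behave alike here and that one cannot stand in for the other.

On these data alone, the true size of both steps stays open, since the value of compound 3 lies somewhere past its limit. Also open, as far as these compounds go, is whether a chlorine, a methoxy group or an amine at the same place would follow fluoro or cyano in this read-out.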